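A Methoxyphenyl Arm Replaces Thiophene on the Shared Core

The source may report more compounds than this note shows. Statements on the series, on what has been measured and on what is new or still open speak of the compounds shown alone.

Compound 2 `Cc1ccc2[nH]c3c(c2c1)CC[C@]1(C3=O)[C@@H](c2cccs2)[C@@H](c2ccccc2)N[C@@]12C(=O)Nc1ccccc12` gives 14000 nM in a functional assay on MCF7 cells (Homo sapiens) for antiproliferative activity, read by MTT assay, with a stated time of 48 h; a lower number here means a stronger inhibitor, a higher number a weaker inhibitor. Its two measured neighbours sit close by: compound 1 `Cc1ccc2[nH]c3c(c2c1)CC[C@]1(C3=O)[C@@H](c2ccccc2)[C@@H](c2ccccc2)N[C@@]12C(=O)Nc1ccccc12` gives 19000 nM, and compound 3 `O=C1Nc2ccccc2[C@]12N[C@H](c1ccccc1)[C@H](c1cccs1)[C@@]21CCc2c([nH]c3ccccc23)C1=O` gives 15000 nM, both within the scatter of compound 2. Compound 4 `COc1ccc([C@H]2[C@@H](c3ccccc3)N[C@@]3(C(=O)Nc4ccccc43)[C@]23CCc2c([nH]c4ccc(C)cc24)C3=O)cc1` differs from compound 2 in one place: 4-methoxyphenyl in place of thiophen-2-yl on a saturated ring carbon. Among the compounds with values here, the only measured step at this saturated carbon, a 1.4-fold lower number from compound 1 to compound 2 (0.13 log units; within the scatter), exchanged phenyl for thiophen-2-yl and stayed within the scatter; the step of a 1.1-fold higher number from compound 2 to compound 3 (0.03 log units; within the scatter) concerns another place and was likewise flat. A 4-methoxyphenyl has not been tried here. Because the step of a 1.4-fold lower number from compound 1 to compound 2 (0.13 log units; within the scatter) stayed within the scatter, the change is estimated at a 1.1-fold higher number from compound 2 to compound 4 (0.06 log units; within the scatter) in this assay, no real shift. Compound 4 is therefore expected to give 16000 nM, within a range from 7000 nM to 40000 nM.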

Compound 4, half-maximal inhibitory concentration: 18000 nM
Compound 4: the middle estimate sits 1.1-fold (0.05 log units) below what was measured; the range from low to high includes it.
By their numbers in this assay, from the lowest: compounds 2, 3, 4 and 1 (each within the scatter of the next).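

In this assay a larger group at this saturated ring carbon still brings no real shift: 4-methoxyphenyl in place of thiophen-2-yl gives a 1.3-fold higher number from compound 2 to compound 4 (0.11 log units; within the scatter). Methoxy in place of hydrogen on the aromatic ring gives a 1.1-fold lower number from compound 1 to compound 4 (0.02 log units; within the scatter). Phenyl, thiophen-2-yl and 4-methoxyphenyl thus all lie within the scatter of one another at this carbon, and no supporting data offer an explanation. Still open, as far as these compounds go, is whether a group of another kind here, such as an amine or a carboxylic acid, would move the number beyond the scatter.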